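Swapping pentyl for (tert-butyl)sulfanyl on an acylguanidine core

The compounds below may be only part of what the source reports. "The series", "measured", "known", "first", "only" and "open" are said of these compounds alone.

Measured compounds:
compound 1, `CCN(CC)Cc1cc(Br)c(S(C)(=O)=O)cc1C(=O)N=C(N)N`, 9500 nM
compound 2, `CCCCCc1cc(C)c(C(=O)N=C(N)N)cc1S(C)(=O)=O`, 27 nM

Both compounds were tested in a functional assay for inhibition of sodium/hydrogen exchanger (Oryctolagus cuniculus); a higher number here means a weaker inhibitor, a lower number a stronger inhibitor. Compound 2 has the lowest number of the two, and the gap to compound 1 lies well beyond the usual scatter of repeat measurements, so compound 2 is clearly the stronger inhibitor of the pair. Compound 1 carries different groups at several places of the shared core, so no single change can be read from that pair.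

The next compound, compound 3, `Cc1cc(SC(C)(C)C)c(S(C)(=O)=O)cc1C(=O)N=C(N)N`, has not yet been measured. It differs from compound 2 in one place: (tert-butyl)sulfanyl in place of pentyl on an aromatic carbon. The group leaving and the group entering are of the same size in heavy atoms, and the surroundings on the ring stay as they are. Among the compounds with values here, with no measured step of this kind to lean on, only a small shift is expected. The expected step is a 1.9-fold higher number from compound 2 to compound 3 (0.27 log units; within the scatter), close to the scatter rather than beyond it. For compound 3 the estimate in this assay is 50 nM, with a range from 15 nM to 200 nM.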

Compound 3, half-maximal inhibitory concentration: 22 nM
For compound 3 the middle estimate is 2.3-fold (0.36 log units) above the measured one; low and high end bracket the measured number.
By their numbers in this assay, from the lowest: compounds 3 and 2 (each within the scatter of the next); then compound 1.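

In this assay the swap of pentyl for (tert-butyl)sulfanyl gives a 1.2-fold lower number from compound 2 to compound 3 (0.09 log units; within the scatter) and so leaves the two compounds indistinguishable. Within the data shown here, this is the first comparison in the set that changes only one place, and it shows that this aromatic carbon, ortho to a methylsulfonyl group, tolerates a change from a straight carbon chain to a branched group joined through sulfur, with the heavy-atom count unchanged and one hydrogen-bond acceptor added by the count. No measurement shown here accounts for why the two groups read alike.

Among these compounds, the result covers only two groups of equal size at this position, so it remains open whether a much shorter chain, a longer chain, an amine or a carboxylic acid would be tolerated as well. As far as these compounds go, it also remains open which feature sets compound 1 at 9500 nM apart from the other two compounds, as that compound differs from them in several places and no single group can be held responsible.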